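The compounds below may be only part of what the source reports. "The series", "measured", "known", "first", "only" and "open" are said of these compounds alone.

Two members of the series have numbers in a functional assay on CHO.K1 cells for antagonist activity at prostaglandin D2 receptor 2 (Homo sapiens), read by GTPgammaS binding, with a stated time of 1 h; on this read-out higher numbers stand for weaker inhibition and lower numbers for stronger inhibition. Compound 1 `Cc1c(Cc2ccccc2S(=O)(=O)c2ccccc2F)c2c(n1CC(=O)O)CCNC2=O` gives 3.6 nM. Compound 2 `Cc1c(Cc2ccccc2S(=O)(=O)c2ccc(OC(F)(F)F)cc2)c2c(n1CC(=O)O)CCNC2=O` gives 6.6 nM; it is separated from compound 1 only by a 1.8-fold higher number from compound 1 to compound 2 (0.26 log units; within the scatter), so on the numbers shown the two cannot be told apart, and compound 2 sets no clear end of the series. Compound 3 `CCS(=O)(=O)c1ccccc1Cc1c2c(n(CC(=O)O)c1C)CCNC2=O` is next: ethyl in place of 4-(trifluoromethoxy)phenyl on a sulfonyl sulfur. Within the data shown here, no measured step exchanges the aromatic group on the sulfonyl sulfur for a chain; the one step at that position, a 1.8-fold higher number from compound 1 to compound 2 (0.26 log units; within the scatter), swaps one aryl for another and stays within the scatter, so it says little about removing the ring altogether. That removal is a larger change than anything measured, and the expectation in this assay is a higher number with wide uncertainty. Compound 3 is expected at 15 nM, within 3 nM to 80 nM. The expected step is a 2.3-fold higher number from compound 2 to compound 3 (0.36 log units; beyond the scatter).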

Compound 3, half-maximal inhibitory concentration: 550 nM
The estimate for compound 3 lay 37-fold (1.56 log units) below the measured number; the measured number lies above the stated range.
By their numbers in this assay, from the lowest: compounds 1 and 2 (each within the scatter of the next); then compound 3.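

In this assay, the sulfonyl sulfur proves far from indifferent to what it carries: ethyl in place of 4-(trifluoromethoxy)phenyl gives an 83-fold higher number from compound 2 to compound 3 (1.92 log units; beyond the scatter), and ethyl in place of 2-fluorophenyl gives a 150-fold higher number from compound 1 to compound 3 (2.18 log units; beyond the scatter). The earlier exchange of one aryl for another gave only a 1.8-fold higher number from compound 1 to compound 2 (0.26 log units; within the scatter), which lies within the scatter, so that step gave no sign of how much the position depends on carrying an aromatic ring. Among the three compounds, the change that matters at this position is from an aromatic ring to ethyl, not from one of the two aryl groups to the other.

Still open, from the compounds shown here alone, is whether an aromatic ring is required here, or whether a cyclohexyl group, a benzyl group or a longer chain such as butyl on the sulfonyl sulfur would bring the number back towards those of compound 1 and compound 2. Nothing available explains the size of these steps.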